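Swapping butylamino for cyano on a cytotoxicity series

A few compounds are considered here, and "the series" means these few. Any claim that something is new, unique, unknown or untested is made for them only; others in the source may bear on it.

Measured so far:
Compound 1 (`CCCCc1ccc(C(=O)N/N=C/c2ccc([N+](=O)[O-])o2)cc1`) gives 19600 nM
Compound 2 (`CCCCNc1ccc(C(=O)N/N=C/c2ccc([N+](=O)[O-])o2)cc1`) gives 12000 nM

Both numbers come from an ADME assay on U2OS cells (Homo sapiens) for cytotoxicity (a higher number here means that more compound is tolerated, a lower number that less compound is tolerated), and they lie within the usual scatter of each other, so compound 2 cannot be ranked against compound 1. The next compound is compound 3 (`N#Cc1ccc(C(=O)N/N=C/c2ccc([N+](=O)[O-])o2)cc1`), which carries cyano in place of butylamino on an aromatic carbon.

Among the measured compounds shown here, only one measured step bears on this change, as it concerns the same place on the ring. Putting butylamino in place of butyl gave a 1.6-fold lower number from compound 1 to compound 2 (0.21 log units; within the scatter) and that step left the butyl chain in place. For the measured compounds named here, the new change removes the chain altogether, so the measured step covers only part of it, and no measured compound carries cyano. With no evidence pointing either way, no step beyond the scatter is expected in this assay, although the uncertainty is wide. As a step, the expectation is small (a 1.7-fold higher number from compound 2 to compound 3 (0.22 log units; within the scatter)). The estimated value for compound 3 is 20000 nM (expected range 7000 nM to 60000 nM).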

Compound 3, half-maximal cytotoxic concentration: 21400 nM
Beside the measured number, compound 3's estimate is 1.1-fold (0.03 log units) below it, and the stated range covers the measured number.
By their numbers in this assay, from the lowest: compounds 2, 1 and 3 (each within the scatter of the next).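

In this assay, the aromatic carbon para to a large group has now carried three different groups, and the numbers do not separate them: cyano in place of butylamino gives a 1.8-fold higher number from compound 2 to compound 3 (0.25 log units; within the scatter), while cyano in place of butyl gives a 1.1-fold higher number from compound 1 to compound 3 (0.04 log units; within the scatter). Butylamino has 5 heavy atoms and 1 hydrogen-bond donor, cyano has 2 heavy atoms and 0 hydrogen-bond donors, so for these three compounds a substantial change in the group at this position still leaves the read-out within the scatter. No independent measurement is available to explain this result.

On these data alone, whether this tolerance extends to other groups at this position, such as a carboxylic acid, a primary amine or a much longer chain, remains open. These compounds differ only at this one position, so they also cannot show whether changes elsewhere on the shared core would move the number beyond the scatter.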